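This account rests on a few compounds, and the source may have more. Where it says the series, first, only, none or still open, it means among the compounds named here.

In a functional assay on MDA-MB-231 cells (Homo sapiens) for antiproliferative activity, read by CCK-8 assay, with a stated time of 48 h (a higher number here means a weaker inhibitor, a lower number a stronger inhibitor), compound 1 `CNC(=O)/C=C/CN1CC(Oc2ccc(Oc3c(-c4ccc(F)cc4)sc4cc(O)ccc34)cc2)C1` gives > 50000 nM, a limit.
In this assay compound 2 `O=C(/C=C/CN1CC(Oc2ccc(Oc3c(-c4ccc(F)cc4)sc4cc(O)ccc34)cc2)C1)N1CCC1` gives > 50000 nM, a limit.

Compound 2 has no number, only (the limit of > 50000 nM in this assay, at which 2 of the 2 values shown sit). Among the compounds with values here, the single measured step is a step that the two limits leave unreadable from compound 1 to compound 2, so it offers no size to carry forward. Compound 3 `C=C(C)C(=O)N1CC(Oc2ccc(Oc3c(-c4ccc(F)cc4)sc4cc(O)ccc34)cc2)C1` replaces the whole group on the amine nitrogen in the four-membered ring: (1-methylethenyl)carbonyl in place of 3-((azetidin-1-yl)carbonyl)prop-2-en-1-yl on an amine nitrogen in a ring. With no readable step behind it, any expectation in this assay is loose: compound 3 probably stays weak, and a further limit is quite possible. The expected step is an at least 1.6-fold lower number from compound 2 to compound 3 (0.22 log units; that floor lies within the scatter), towards stronger inhibition if it can be read at all. For compound 3 the estimate is 30000 nM, with an expected range of 8000 nM to 60000 nM.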

Compound 3, half-maximal inhibitory concentration: > 50000 nM
Compound 3: only a limit was reported (the forecaster's own chance of this, stated with the estimate: 60%); middle value at least 1.6-fold (0.22 log units) away from the limit.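

Within the data shown here, compound 3, like compound 1 and compound 2, gives only a limit in this assay, so no step among the three can be read: the limit of > 50000 nM in this assay, at which 3 of the 3 values shown sit. The compounds shown leave open whether any group on the ring amine nitrogen gives a readable value.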